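This account rests on a few compounds, and the source may have more. Where it says the series, first, only, none or still open, it means among the compounds named here.

Measured compounds:
Compound 1, `Cc1cc(C(=O)O)ccc1CN1CCC[C@H](OC(c2cc(Cl)cc(Cl)c2)C(C)O)[C@@H]1c1ccccc1`, 5300 nM.
Compound 2, `Nc1cc(C(=O)O)ccc1CN1CCC[C@H](O[C@H](CO)c2cc(Cl)cc(Cl)c2)[C@@H]1c1ccccc1`, 290 nM.
Compound 3, `Cc1cc(C(=O)O)ccc1CN1C(=O)CC[C@H](OCc2cc(Cl)cc(Cl)c2)[C@@H]1c1ccccc1`, 169000 nM.

In an assay on isolated protein for activation of cGMP-dependent protein kinase 1 (Homo sapiens), read by ADP-Glo, with stated times of 30 min and 2 h, in the presence of a further agent that is not named here (a higher number here means that more compound is needed for the effect, a lower number that less compound is needed), compound 1 stands second highest of the three numbers. Compound 2, which differs from it in several places, gives 290 nM, a lower number that lies beyond the scatter. Compound 3 gives 169000 nM, a higher number that also lies beyond the scatter. Within the data shown here, no single-place step between measured compounds is available, so the weight of any one change remains unresolved.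

Compound 4, `Cc1cc(C(=O)O)ccc1CN1CCC[C@H](O[C@H](CF)c2cc(Cl)cc(Cl)c2)[C@@H]1c1ccccc1`, is not yet measured. Compared with compound 1 it carries a group of 11 heavy atoms (8 carbon, 1 fluorine, 2 chlorine; one six-membered aromatic ring of carbon only) in place of a group of 12 heavy atoms (9 carbon, 1 oxygen, 2 chlorine; one six-membered aromatic ring of carbon only), on an oxygen on a saturated carbon.

Among the measured compounds shown here, without a measured step of this kind, the expected step in this assay is a small one, and it is estimated as a 2.1-fold lower number from compound 1 to compound 4 (0.33 log units; beyond the scatter), leaning toward a lower number, because compound 2, the only measured neighbour with a single defined stereocentre at that position, gives 290 nM. For compound 4 the estimate is 2500 nM, with a range from 600 nM to 10000 nM.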

Compound 4, half-maximal effective concentration: 9100 nM
For compound 4 the middle estimate is 3.6-fold (0.56 log units) below the measured one; measured number inside the range.
By their numbers in this assay, from the lowest: compound 2; then compounds 1 and 4 (each within the scatter of the next); then compound 3.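

In this assay, setting the group with 11 heavy atoms, including 1 fluorine, on the oxygen in place of the group with 12 heavy atoms, including 1 oxygen, gives a 1.7-fold higher number from compound 1 to compound 4 (0.23 log units; within the scatter) and so no change that can be told from the scatter. Among these compounds, at this position, then, the entering group's 0 hydrogen-bond donors and 0 hydrogen-bond acceptors, against 1 of each in the group that leaves, go with no resolved shift in the number, which the earlier compounds could not show. Nothing available gives a reason for this result.

Among the compounds shown here, the single step changes the atom count, the fluorine and the defined stereocentre together, so their separate weights stay unresolved. Going by these compounds, whether an amine or a longer chain in that group would be tolerated equally remains open.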